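The compounds below may be only part of what the source reports. "The series", "measured", "known", "first", "only" and "open" are said of these compounds alone.

Of the compounds shown here, two have been tested in a functional assay (aorta) with Rattus norvegicus as the target; on this read-out lower numbers stand for lower potency and higher numbers for higher potency (the scale is a negative logarithm). Compound 1 `CCC(=O)c1ccc2c(c1)C(n1ccccc1=O)=CC(C)(C)O2` gives 6.63 in this assay. Compound 2 `CC1(C)C=C(n2ccccc2=O)c2cc(C=C(C#N)C#N)ccc2O1` gives 6.95 in this assay, the higher of the two numbers, the change being a number 0.32 log units higher from compound 1 to compound 2 (beyond the scatter).

Compound 3 `CC(=O)Oc1ccc2c(c1)C(n1ccccc1=O)=CC(C)(C)O2` has not yet been measured. It differs from compound 2 by acetoxy in place of 2,2-dicyanoethenyl on an aromatic carbon. Going by the values given here, no measured step exchanges the 2,2-dicyanoethenyl group for acetoxy, so nothing bears directly on this change; the only step known, from propanoyl to 2,2-dicyanoethenyl, raised the number, which suggests only that the 2,2-dicyanoethenyl group sits somewhat above another substituent at this position. The expected change for compound 3 is therefore a moderate loss on leaving it, estimated as a number 0.40 log units lower from compound 2 to compound 3 (beyond the scatter), though the uncertainty is wide. Compound 3 is estimated at 6.55 in this assay, between 5.9 and 7.2.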

Compound 3, logarithm of the reciprocal of the active concentration, log(1/C): 5.6
Compound 3: middle estimate off by 0.95 log units, on the high side; the whole stated range lies above it.
By their numbers in this assay, from the lowest: compound 3; then compound 1; then compound 2.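

In this assay, the aromatic carbon carrying these groups proves far more sensitive to the choice of substituent than the first pair suggested: the value falls by a large margin when acetoxy enters, with a number 1.35 log units lower from compound 2 to compound 3 (beyond the scatter) and a number 1.03 log units lower from compound 1 to compound 3 (beyond the scatter). Both steps dwarf the modest one between propanoyl and 2,2-dicyanoethenyl, which leaves compound 3 the least potent of the three and shows that the loss is not tied to leaving one particular group. Nothing available explains why acetoxy costs so much here.

Going by these compounds alone, only three groups are compared at this position, all on the shared core, so it remains open whether the drop is peculiar to acetoxy. An amine, a carboxylic acid or a longer chain on this carbon could fall nearer either end of the range.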